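The source may report more compounds than this note shows. Statements on the series, on what has been measured and on what is new or still open speak of the compounds shown alone.

Measured compounds in a functional assay on DLD-1 cells (Homo sapiens), read by microscopy and crystal violet staining, with a stated time of 20 h, tested at 10 ug/mL; a higher number here means more inhibition at the concentration tested (going by the name of the read-out), a lower number less inhibition:
compound 1 `O=C1NC(=S)S/C1=C\C=C\c1ccccc1`, compound 1 gives 81%
compound 2 `COc1ccccc1/C=C/C=C1\SC(=S)NC1=O`, compound 2 gives 69%
compound 3 `O=C1NC(=S)S/C1=C\C=C\c1ccccc1Cl`, compound 3 gives 80%

Compound 2 stands lowest of the three numbers in this assay. The step of a number 12 percentage points lower from compound 1 to compound 2 (beyond the scatter) lies beyond the scatter, as does the step of a number 11 percentage points higher from compound 2 to compound 3 (beyond the scatter), while the step of a number 1 percentage points lower from compound 1 to compound 3 (within the scatter) stays within it. Both steps away from compound 2 are modest in size.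

Compound 4 `Cc1ccccc1COc1ccccc1/C=C/C=C1\SC(=S)NC1=O` is the next member. Compared with compound 2 it carries 2-methylphenyl in place of hydrogen on a saturated chain carbon bound to an oxygen on an aromatic ring

For the measured compounds named here, no measured step touches this place: the steps recorded so far exchange groups on an aromatic carbon only, and none enlarges the methoxy group itself. The three measured steps are therefore only a loose guide; they show that the changes made so far in this series moved the read-out by modest amounts at most. On that basis a change of at most modest size is expected for compound 4, with no firm direction, and the estimate is a number 3 percentage points lower from compound 2 to compound 4 (within the scatter). Compound 4 is thus estimated at 66%, with a range from 45% to 84%.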

Compound 4, a percentage reported as inhibition, at one concentration (the size of the read-out at that concentration, not a potency): 73%
Beside the measured number, compound 4's estimate is 7 percentage points below it, and the stated range covers the measured number.
By their numbers in this assay, from the lowest: compounds 2, 4, 3 and 1 (each within the scatter of the next, the first and the last beyond it).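

In this assay, 2-methylphenyl in place of hydrogen on a saturated chain carbon bound to an oxygen on an aromatic ring gives a number 4 percentage points higher from compound 2 to compound 4 (within the scatter). For the compounds shown here, this is the first measured change away from an aromatic carbon, and it shows that a group of 7 heavy atoms with one six-membered aromatic ring can stand at this place without a step beyond the scatter. No measured evidence at hand bears on the reason for this outcome.

Still open, going by these compounds, is how an unsubstituted phenyl, a longer chain, an amine or a carboxylic acid would read at this place, and whether the methyl on the 2-methylphenyl matters. With one tested concentration, the read-out also leaves open whether compound 2 and compound 4 would separate at lower concentrations.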